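Cyano for hydrogen on the pendant ring of compound 1

This account rests on a few compounds, and the source may have more. Where it says the series, first, only, none or still open, it means among the compounds named here.

Measured compounds:
compound 1 `C/C(=C\c1cc(-c2ccccc2)cs1)C(N)=O` 2680 nM
compound 2 `C/C(=C\c1nc(-c2ccc(F)cc2)cs1)C(N)=O` 3300 nM
compound 3 `C/C(=C\c1cc(-c2ccccc2C)cs1)C(N)=O` 4920 nM

In a functional assay on MCF7 cells (Homo sapiens) for cytotoxicity, read by CCK-8 assay, with a stated time of 24 h (on this read-out higher numbers stand for weaker inhibition and lower numbers for stronger inhibition), compound 1 gives the lowest of the three numbers shown, though its nearest neighbour compound 2 and its furthest neighbour compound 3 both sit within the scatter of it, so no order among the three can be claimed.

Compound 4 `C/C(=C\c1cc(-c2ccc(C#N)cc2)cs1)C(N)=O` has not yet been measured. It differs from compound 1 by cyano in place of hydrogen on an aromatic carbon, the cyano sitting para to a large group on the six-membered aromatic ring of carbon only.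

For the measured compounds named here, only one measured step concerns a substituent on that ring: a 1.8-fold higher number from compound 1 to compound 3 (0.26 log units; within the scatter). Going by the values given here, compound 2 carries a fluorine on the corresponding ring but also a different core, so its value shows only that it lies near compound 1. Among the compounds with values here, no step with a cyano exists among the measured compounds.

On this basis compound 4 is expected to show no step beyond the scatter, a 1.0-fold higher number from compound 1 to compound 4 (0.00 log units; within the scatter). The estimate for compound 4 is 2700 nM, with a range from 1100 nM to 6500 nM.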

Compound 4, half-maximal inhibitory concentration: 240 nM
Compound 4: the middle estimate sits 11-fold (1.05 log units) above what was measured; measured number outside the range, below it.
By their numbers in this assay, from the lowest: compound 4; then compounds 1, 2 and 3 (each within the scatter of the next).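

In this assay, the pendant ring of compound 1 tolerates a change that moves the number well beyond the scatter: cyano in place of hydrogen, para to a large group, gives an 11-fold lower number from compound 1 to compound 4 (1.05 log units; beyond the scatter), whereas methyl in place of hydrogen on an aromatic carbon of that ring gives only a 1.8-fold higher number from compound 1 to compound 3 (0.26 log units; within the scatter). These two steps differ in both the group and its place on the ring, so they cannot separate the effect of one from the other. No measurement shown here accounts for the size of the cyano step.

From the compounds shown here alone, what an amine, a carboxylic acid or a methoxy group would do at this position remains open, and with it whether the step belongs to cyano alone. Also open, going by these compounds, is whether cyano elsewhere on the ring, or on the corresponding ring of compound 2, would give a step of similar size.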